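Caspase-8 series: amine swap at the chain carbon

A few compounds are considered here, and "the series" means these few. Any claim that something is new, unique, unknown or untested is made for them only; others in the source may bear on it.

Of the compounds shown here, three have been measured in an assay for inhibition of Caspase-8 (Homo sapiens); on this read-out lower numbers stand for stronger inhibition and higher numbers for weaker inhibition. Compound 1 `CCC(C(=O)N[C@@H](CC(=O)O)C(=O)CSCc1ccccc1)n1ccnc(NCC2COc3ccccc3O2)c1=O` gives 8220 nM. Compound 2 `CCCCCCN(C)CNCC(=O)[C@H](CC(=O)O)NC(=O)C(CC)n1cc(CC)nc(NCc2nonc2C)c1=O` gives 9540 nM. Compound 3 `CCC(C(=O)N[C@@H](CC(=O)O)C(=O)CNCN1CCc2ccccc2C1)n1ccnc(NCc2nonc2C)c1=O` gives 7380 nM, which lies within the scatter of compound 1 and of compound 2; the three values are not separable from one another on this read-out.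

Compound 4 `CCCCCCN(C)CNCC(=O)[C@H](CC(=O)O)NC(=O)C(CC)n1ccnc(NCc2nonc2C)c1=O` is not yet measured. It differs from compound 3 in one place: hexyl(methyl)amino in place of 1,2,3,4-tetrahydroisoquinolin-2-yl on a saturated chain carbon bound to an amine nitrogen. Within the data shown here, no pair of measured compounds differing only in this way is available, so no measured step guides the expectation. Compound 2 carries the same hexyl(methyl)amino group on the same chain and gives 9540 nM, a value within the scatter of compound 3. On that basis the step from compound 3 to compound 4 is expected to stay within the scatter, and a 1.2-fold higher number from compound 3 to compound 4 (0.06 log units; within the scatter) is the estimate. For compound 4 the estimated value in this assay is 8500 nM, with a range from 4500 nM to 16000 nM.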

Compound 4, half-maximal inhibitory concentration: > 10000 nM
Compound 4: no number, only a limit; the forecaster's own chance of this, stated with the estimate: 10%; middle value at least 1.1-fold (0.07 log units) from the limit.
By their numbers in this assay, from the lowest: compounds 3, 1 and 2 (each within the scatter of the next). At a limit, above all of these: compound 4.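

In this assay the reading for compound 4 is a limit of the assay, not a number: the limit of > 10000 nM in this assay, at which 1 of the 4 values shown sits. Hexyl(methyl)amino in place of 1,2,3,4-tetrahydroisoquinolin-2-yl on a saturated chain carbon bound to an amine nitrogen gives an at least 1.3-fold higher number from compound 3 to compound 4 (0.13 log units; that floor lies within the scatter), the first step read for this position, though only as a floor. Hydrogen in place of ethyl on an aromatic carbon gives an at least 1.0-fold higher number from compound 2 to compound 4 (0.02 log units; that floor lies within the scatter), so neither step points to a lower number, and both floors stay too small to show a real change.

From the compounds shown here alone, the true size of both steps stays unknown while compound 4 rests on a limit. Also open, going by these compounds, is whether a smaller amine such as dimethylamino, or a morpholine ring, on the same saturated chain carbon would move the number beyond the scatter.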